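The source may hold more compounds than are shown below. What is called first, only, known or untested is meant among the compounds shown, and "the series" means these compounds.

Measured so far, in a functional assay on MDA-MB-231 cells (Homo sapiens) for antiproliferative activity, with a stated time of 72 h; a lower number here means a stronger inhibitor, a higher number a weaker inhibitor:

Compound 1, `COc1ccc(C2CC(c3ccc(Cl)cc3)=NN2c2nc(-c3ccccc3)c(C#N)c(=O)n2C)cc1` — 11100 nM
Compound 2, `COc1ccc(C2=NN(c3nc(-c4ccccc4)c(C#N)c(=O)n3C)C(c3ccc(OC)cc3)C2)cc1` — 16200 nM
Compound 3, `Cn1c(N2N=C(c3ccccc3)CC2c2ccc(Cl)cc2)nc(-c2ccc(Cl)cc2)c(C#N)c1=O` — 25100 nM

Compound 1 and compound 2 differ in one place only: methoxy in place of chloro on an aromatic carbon. This gave a 1.5-fold higher number from compound 1 to compound 2 (0.16 log units; within the scatter), so the two compounds cannot be told apart by this assay.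

Compound 3 shares the same kind of scaffold but the difference between its core and the core of compound 1 is not broken down here. Its value sits near that of compound 2, within the scatter, and further from compound 1, beyond it.

Compound 4, `COc1ccc(C2CC(c3ccccc3)=NN2c2nc(-c3ccc(Cl)cc3)c(C#N)c(=O)n2C)cc1`, is not yet measured. It is made from compound 3 by the same change: methoxy in place of chloro on an aromatic carbon. The place is the same in words as in the first pair.

Among the compounds with values here, the only guide is the first pair, where the change left the number essentially unmoved. The step from compound 3 to compound 4 is therefore expected to be small, about a 1.3-fold higher number from compound 3 to compound 4 (0.11 log units; within the scatter), because the earlier change gave a 1.5-fold higher number from compound 1 to compound 2 (0.16 log units; within the scatter). Compound 4 is estimated at 32000 nM, likely between 15000 nM and 65000 nM.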

Compound 4, half-maximal inhibitory concentration: 19500 nM
Compound 4: the middle estimate sits 1.6-fold (0.22 log units) above what was measured; the range from low to high includes it.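

On the second core, putting methoxy in place of chloro gave a 1.3-fold lower number from compound 3 to compound 4 (0.11 log units; within the scatter) in this assay, so compound 3 and compound 4 cannot be told apart by this measurement, just as the first pair could not. The two steps also agree with each other as far as this measurement can tell: the same change on two cores in this assay, a 1.5-fold higher number (0.16 log units; within the scatter) from compound 1 to compound 2 and a 1.3-fold lower number (0.11 log units; within the scatter) from compound 3 to compound 4, 1.9-fold (0.27 log units) apart, within the scatter of two such steps. This shows that the change made no step beyond the scatter on either core, but it does not show that a real effect of the change carries over from one core to the other, and any true difference between the cores smaller than the scatter would stay hidden.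

The compounds shown leave open whether a group other than chloro or methoxy, such as an amine, a carboxylic acid or a longer chain, would give a step beyond the scatter on these cores. Within the data shown here, with only two cores carrying this change, it also remains open whether the same result would hold on a third core.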